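Alpha-ketoheterocycle series: oxadiazole to tetrazole at the carbonyl

The source may report more compounds than this note shows. Statements on the series, on what has been measured and on what is new or still open speak of the compounds shown alone.

Of the compounds shown here, three have numbers so far. Compound 1 `O=C(CCCCCCc1ccccc1)c1nnc(-c2cccs2)o1` gives 2500 nM in an assay for inhibition of Fatty-acid amide hydrolase 1 (Rattus norvegicus); on this read-out higher numbers stand for weaker inhibition and lower numbers for stronger inhibition. Compound 2 `COC(=O)c1cccc(-c2nnc(C(=O)CCCCCCc3ccccc3)o2)n1` gives 8 nM. Compound 3 `O=C(CCCCCCc1ccccc1)c1ncno1` gives 4 nM, the lowest number of the three; its gap to compound 2 lies within the scatter, its gap to compound 1 well beyond it. Going by the values given here, no step between two measured compounds that differ in one place is available.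

Compound 4 `O=C(CCCCCCc1ccccc1)c1nnn[nH]1` is not yet measured. It differs from compound 3 by 1H-tetrazol-5-yl in place of 1,2,4-oxadiazol-5-yl on a carbonyl carbon. Nothing measured here follows this exact change, so the expectation rests on the change alone. Compound 4 is expected to give a higher number, a step of a 50-fold higher number from compound 3 to compound 4 (1.70 log units; beyond the scatter) beyond the scatter, with the estimate for compound 4 at 200 nM, between 30 nM and 2000 nM.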

Compound 4, half-maximal inhibitory concentration: 600 nM
For compound 4 the middle estimate is 3.0-fold (0.48 log units) below the measured one, within the range that was stated.
By their numbers in this assay, from the lowest: compounds 3 and 2 (each within the scatter of the next); then compound 4; then compound 1.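

With the saturated chain held fixed, the group on the carbonyl carbon alone moves the number well beyond the scatter in this assay: a 150-fold higher number from compound 3 to compound 4 (2.18 log units; beyond the scatter) with 1H-tetrazol-5-yl in place of 1,2,4-oxadiazol-5-yl. Going by these compounds alone, this is the first one-place step, and it shows that this position is sensitive to this exchange of rings. Nothing available explains the size of the step.

Still open, as far as these compounds go, is how compound 4 would respond to a methyl group on the tetrazole ring. Also open, from the compounds shown here alone, is how compound 3 would respond to a carboxylic acid on its ring.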